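Diaryl alkenes at the assay limit: the acetyl step

The source may report more compounds than this note shows. Statements on the series, on what has been measured and on what is new or still open speak of the compounds shown alone.

Of the compounds shown here, two have been measured so far. Compound 1 is `C=C(c1cc(OC)cc(OC)c1)c1ccc(OC)c(OC)c1`, and in a functional assay on HCT-116 cells (Homo sapiens) for cytotoxicity, read by scintillation counting and thymidine incorporation, with a stated time of 72 h (on this read-out higher numbers stand for weaker inhibition and lower numbers for stronger inhibition), compound 1 gives > 10000 nM, which is a limit and not a number. Compound 2 is `COc1cc(OC)cc(C(=CCCN(C)C)c2ccc(OC)c(OC)c2)c1`. In this assay compound 2 gives > 10000 nM, which is also a limit. Compound 2 therefore has no numerical position in the series, and its standing is simply (the limit of > 10000 nM in this assay, at which 2 of the 2 values shown sit).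

The next compound is compound 3, `COc1cc(OC)cc(C(=CC(C)=O)c2ccc(OC)c(OC)c2)c1`. It carries acetyl in place of 2-(dimethylamino)ethyl on a double-bonded chain carbon bound to a double-bonded chain carbon.

Within the data shown here, only one measured step bears on this change, a step that the two limits leave unreadable from compound 1 to compound 2. It has no size to carry forward and gives no direction. The expectation in this assay therefore rests on (the limit of > 10000 nM in this assay, at which 2 of the 2 values shown sit), and no shift beyond the scatter is expected. The expected step is a step that the limit leaves unreadable from compound 2 to compound 3. A reported limit is the likeliest result. For compound 3 the estimated value is 15000 nM, with an expected range from 5000 nM to 50000 nM.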

Compound 3, half-maximal inhibitory concentration: > 10000 nM
Compound 3: no number, only a limit; the forecaster's own chance of this, stated with the estimate: 85%; the middle value lies beyond the limit too.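

Compound 1, compound 2 and compound 3 all stand at a limit and not at a number, so no new step among them can be read: the limit of > 10000 nM in this assay, at which 3 of the 3 values shown sit.

Left open is whether any group on a double-bonded chain carbon bound to a double-bonded chain carbon brings the shared core to a numerical value in this assay.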